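Replacing the aryl group with fluorine on the oxazole core

The source may hold more compounds than are shown below. What is called first, only, known or untested is meant among the compounds shown, and "the series" means these compounds.

Compound 1 `N#Cc1cccc(-c2cnc(C(=O)CCCCCCc3ccccc3)o2)c1`: 15 nM
Compound 2 `NS(=O)(=O)c1ccc(-c2cnc(C(=O)CCCCCCc3ccccc3)o2)cc1`: 10 nM
Compound 3 `O=C(CCCCCCc1ccccc1)c1ncc(-c2ncccc2C(=O)O)o1`: > 50 nM

In an assay (Rattus norvegicus) for inhibition of Fatty-acid amide hydrolase 1 (Homo sapiens) (a lower number here means a stronger inhibitor, a higher number a weaker inhibitor), compound 1 gives 15 nM and compound 2 gives 10 nM. As far as these compounds go, for compound 3 this assay reports only a limit, > 50 nM, so its true number is unknown. Within the data shown here, the one measured step that bears here, an at least 3.3-fold higher number from compound 1 to compound 3 (0.52 log units; beyond the scatter), shows that swapping the 3-cyanophenyl group for 3-carboxypyridin-2-yl weakens inhibition (the limit of > 50 nM in this assay, at which 1 of the 3 values shown sits).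

Compound 4 `O=C(CCCCCCc1ccccc1)c1ncc(F)o1` carries the change (fluoro in place of 3-carboxypyridin-2-yl on an aromatic carbon). Among the measured compounds shown here, no measured compound lacks an aromatic group at this position, so this is a larger departure than the measured step. Compound 4 is expected to give 250 nM, within 40 nM to 2000 nM. The expected step is a step that the limit leaves unreadable from compound 3 to compound 4, likely again reported only as a limit.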

Compound 4, inhibition constant: 30 nM
For compound 4 the middle estimate is 8.3-fold (0.92 log units) above the measured one; the measured number lies below the stated range.
By their numbers in this assay, from the lowest: compounds 2, 1 and 4 (each within the scatter of the next, the first and the last beyond it). At a limit, above all of these: compound 3.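

In this assay, a lone fluoro on this aromatic carbon, next to the ring oxygen, gives a number that cannot be told apart from that of the 3-cyanophenyl group: a 2.0-fold higher number from compound 1 to compound 4 (0.30 log units; within the scatter). An aromatic ring at this position is therefore not required for inhibition at this level. The comparison with the 3-carboxypyridin-2-yl group is less firm, resting on a limit for compound 3: an at least 1.6-fold lower number from compound 3 to compound 4 (0.22 log units; that floor lies within the scatter).

Still open, as far as these compounds go, is whether fluoro itself contributes anything, or whether a hydrogen, a chlorine or a methyl group here would give a similar number.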